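Swapping the Open Chain of Compound 2 for a Ring

A few compounds are considered here, and "the series" means these few. Any claim that something is new, unique, unknown or untested is made for them only; others in the source may bear on it.

In a functional assay on SK-HEP1 cells (Homo sapiens) for inhibition, read by sulforhodamine B assay, with a stated time of 48 h (on this read-out higher numbers stand for weaker inhibition and lower numbers for stronger inhibition), compound 1 (`O=C(Nc1ccc(C(=O)NO)cc1)Nc1ccc(Cl)c(C(F)(F)F)c1`) gives 3800 nM, and compound 3 (`O=C(/C=C/c1ccc(NC(=O)Nc2ccc(Cl)c(C(F)(F)F)c2)cc1)NO`) gives 3200 nM, which is a 1.2-fold lower number from compound 1 to compound 3 (0.07 log units; within the scatter). Compound 2 (`O=C(CCCC(=O)Nc1ccc(NC(=O)Nc2ccc(Cl)c(C(F)(F)F)c2)cc1)NO`) gives only > 10000 nM, which is a limit of the assay and not a number. That is the limit of > 10000 nM in this assay, at which 1 of the 3 values shown sits.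

Compound 4 (`O=C(Nc1ccc(Nc2ncc(C(=O)NO)cn2)cc1)Nc1ccc(Cl)c(C(F)(F)F)c1`) carries 5-(hydroxycarbamoyl)pyrimidin-2-yl in place of the (3-(hydroxycarbamoyl)propyl)carbonyl of compound 2, on a nitrogen on an aromatic ring: 5-(hydroxycarbamoyl)pyrimidin-2-yl in place of (3-(hydroxycarbamoyl)propyl)carbonyl on a nitrogen on an aromatic ring.

For the measured compounds named here, two measured steps bear on this change: an at least 2.6-fold higher number from compound 1 to compound 2 (0.42 log units; beyond the scatter), and an at least 3.1-fold lower number from compound 2 to compound 3 (0.49 log units; beyond the scatter). Neither tests this ring, so the expectation stays loose. A modest move to a lower number is expected, and the estimated step is an at least 2.8-fold lower number from compound 2 to compound 4 (0.45 log units; beyond the scatter). For compound 4 the expected value is 3500 nM, within an estimated range of 900 nM to 10000 nM.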

Compound 4, half-maximal inhibitory concentration: > 10000 nM
Compound 4 was reported as a limit; the forecaster's own chance of this, stated with the estimate: 20%; middle value at least 2.8-fold (0.45 log units) away from the limit.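

Compound 2 and compound 4 are both reported only as a limit of the assay, so no step between them can be read: the limit of > 10000 nM in this assay, at which 2 of the 4 values shown sit.

On these data alone, whether 5-(hydroxycarbamoyl)pyrimidin-2-yl gives stronger or weaker inhibition than (3-(hydroxycarbamoyl)propyl)carbonyl remains open.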